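Indole substituent change on a diterpenoid-indole core

A few compounds are considered here, and "the series" means these few. Any claim that something is new, unique, unknown or untested is made for them only; others in the source may bear on it.

Measured so far:
- Compound 1 `COC(=O)[C@@]1(C)CCC=C2[C@@H]1CC[C@@H](C)[C@]2(C)Cc1c[nH]c2ccc(C)cc12`, 22000 nM in a functional assay on WiDr cells (Homo sapiens) for inhibition, read by sulforhodamine B assay, with a stated time of 48 h; on this read-out lower numbers stand for stronger inhibition of growth and higher numbers for weaker inhibition of growth
- Compound 2 `COC(=O)[C@@]1(C)CCC=C2[C@@H]1CC[C@@H](C)[C@]2(C)Cc1c[nH]c2ccc(F)cc12`, 8000 nM in this assay

Within the data shown here, compound 1 stands highest of the two numbers known in this assay; the only neighbour, compound 2, lies a 2.8-fold lower number from compound 1 to compound 2 (0.44 log units; beyond the scatter) below it. Compound 3 `COC(=O)[C@@]1(C)CCC=C2[C@@H]1CC[C@@H](C)[C@]2(C)Cc1c[nH]c2ccc(OC)cc12` differs from compound 1 by methoxy in place of methyl on an aromatic carbon. Among the measured compounds shown here, no measured step makes this exact exchange; the single step that bears on it, a 2.8-fold lower number from compound 1 to compound 2 (0.44 log units; beyond the scatter), shows that swapping this group on the indole ring for a different group moved the number modestly and toward stronger inhibition. Whether a methoxy behaves like a fluoro here is not known from these two compounds, so the expectation is a small step, if any, from compound 1 to compound 3, with the range kept wide. Compound 3 is therefore expected to give about 15000 nM, between 5000 nM and 40000 nM, which would mean a step of a 1.5-fold lower number from compound 1 to compound 3 (0.17 log units; within the scatter).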

Compound 3, concentration for 50% growth inhibition: 5700 nM
Compound 3: middle estimate off by 2.6-fold (0.42 log units), on the high side; the measured number falls inside the stated range.
By their numbers in this assay, from the lowest: compounds 3 and 2 (each within the scatter of the next); then compound 1.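

Methoxy in place of methyl gives a 3.9-fold lower number from compound 1 to compound 3 (0.59 log units; beyond the scatter) and so adds a second replacement at this indole position that lowers the number beyond the scatter, where the earlier compounds offered only fluoro. Methoxy in place of fluoro gives a 1.4-fold lower number from compound 2 to compound 3 (0.15 log units; within the scatter) and this step stays within the scatter, so compound 2 and compound 3 cannot be separated in this read-out even though the two groups are different. Nothing measured here offers a reason for these results.

The compounds shown leave open whether other groups at this position, such as an amine, a carboxylic acid or a longer chain like ethoxy, would also match compound 2 and compound 3. They also leave open where a plain hydrogen at this position would fall relative to compound 1.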